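This account rests on a few compounds, and the source may have more. Where it says the series, first, only, none or still open, it means among the compounds named here.

Compounds measured in a functional assay on PC-3 cells (Homo sapiens) for inhibition; on this read-out higher numbers stand for weaker inhibition and lower numbers for stronger inhibition:
compound 1, `COc1cc2nc(N3CCN(S(=O)(=O)c4ccc(Br)cc4)CC3)nc(N)c2cc1OC`, 20000 nM;
compound 2, `COc1cc2nc(N3CCN(S(=O)(=O)c4ccc(Cl)s4)CC3)nc(N)c2cc1OC`, 25000 nM;
compound 3, `COc1cc2nc(N3CCN(S(=O)(=O)c4ccc(C)cc4)CC3)nc(N)c2cc1OC`, 30000 nM.

Compound 3 gives the highest of the three numbers, but its gaps to the others are small: a 1.5-fold higher number from compound 1 to compound 3 (0.18 log units; within the scatter) and a 1.2-fold higher number from compound 2 to compound 3 (0.08 log units; within the scatter) both lie within the scatter, as does a 1.3-fold higher number from compound 1 to compound 2 (0.10 log units; within the scatter). All three compounds therefore sit at about the same level in this assay.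

Compound 4, `COc1cc2nc(N3CCN(S(=O)(=O)c4ccc(C(F)(F)F)cc4)CC3)nc(N)c2cc1OC`, differs from compound 3 by trifluoromethyl in place of methyl on an aromatic carbon. Going by the values given here, the one measured step at the same position, a 1.5-fold higher number from compound 1 to compound 3 (0.18 log units; within the scatter), stayed within the scatter, and swapping the whole aromatic ring on the sulfonyl sulfur did no more. A step of similar size is therefore expected here: no change at the digits printed from compound 3 to compound 4 (within the scatter), with no clear direction. Compound 4 is estimated at 30000 nM, in the range 12000 nM to 75000 nM.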

Compound 4, half-maximal inhibitory concentration: 27000 nM
Compound 4: the middle estimate sits 1.1-fold (0.05 log units) above what was measured; measured number inside the range.
By their numbers in this assay, from the lowest: compounds 1, 2, 4 and 3 (each within the scatter of the next).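

Trifluoromethyl, with 4 heavy atoms against 1 for methyl, leaves the number in this assay essentially unchanged (a 1.1-fold lower number from compound 3 to compound 4 (0.05 log units; within the scatter)). The comparisons with the other two compounds also stay flat (a 1.4-fold higher number from compound 1 to compound 4 (0.13 log units; within the scatter)) and (a 1.1-fold higher number from compound 2 to compound 4 (0.03 log units; within the scatter)), so this much added bulk on the ring does not separate compound 4 from compounds 1, 2 and 3. No measured finding is available to explain this flat result.

On these data alone, whether an amine or a carboxylic acid at this ring position would shift the number remains open. So does whether changing the shared core would do so.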